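The compounds below may be only part of what the source reports. "The series", "measured", "known", "first", "only" and "open" are said of these compounds alone.

For the measured compounds named here, compound 3 `CC1(C)CCSC1=O` stands highest of the three numbers so far in a functional assay on the whole organism for inhibition, with Mus musculus as the target (a higher number here means that more compound is needed for the effect, a lower number that less compound is needed), where compound 3 gives 208 mg/kg; compound 2 `CC(C)C1CCSC1=O` gives 145 mg/kg, within the scatter of it, and compound 1 `CC1CCSC1=O` gives 91 mg/kg, the gap being a 2.3-fold higher number from compound 1 to compound 3 (0.36 log units; beyond the scatter). Compound 4 `CC(C)C1(C)CCSC1=O` differs from compound 3 by isopropyl in place of methyl on a saturated ring carbon. Going by the values given here, the one measured step of the same kind, isopropyl in place of methyl on a saturated ring carbon, was a 1.6-fold higher number from compound 1 to compound 2 (0.20 log units; within the scatter), which fell within the scatter. The expected change is therefore a 1.4-fold higher number from compound 3 to compound 4 (0.16 log units; within the scatter), small and perhaps towards a higher number, but not clearly beyond the scatter. Compound 4 is thus estimated to give 300 mg/kg in this assay, with a range from 150 mg/kg to 600 mg/kg.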

Compound 4, dose for half-maximal effect: 154 mg/kg
Estimate against measurement, compound 4: 1.9-fold (0.29 log units) above; measured number inside the range.
By their numbers in this assay, from the lowest: compounds 1, 2, 4 and 3 (each within the scatter of the next, the first and the last beyond it).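

In this assay, the change to isopropyl in place of methyl on a saturated ring carbon now gives a 1.4-fold lower number from compound 3 to compound 4 (0.13 log units; within the scatter), so its direction is not the same on both cores, yet the two steps do not separate: the same change on two cores in this assay, a 1.6-fold higher number (0.20 log units; within the scatter) from compound 1 to compound 2 and a 1.4-fold lower number (0.13 log units; within the scatter) from compound 3 to compound 4, 2.2-fold (0.33 log units) apart, within the scatter of two such steps. Methyl in place of hydrogen now gives a 1.1-fold higher number from compound 2 to compound 4 (0.03 log units; within the scatter), and this too stays in agreement with its earlier step: the same change on two cores in this assay, a 2.3-fold higher number (0.36 log units; beyond the scatter) from compound 1 to compound 3 and a 1.1-fold higher number (0.03 log units; within the scatter) from compound 2 to compound 4, 2.2-fold (0.33 log units) apart, within the scatter of two such steps. Isopropyl in place of hydrogen gives a 1.7-fold higher number from compound 1 to compound 4 (0.23 log units; within the scatter), which also lies within the scatter.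

The compounds shown carry only methyl and isopropyl here. They leave open what an amine, a carboxylic acid or a longer chain on this ring carbon would give.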